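Ring Size at the Chain End: Compound 3 to Compound 4

The compounds below may be only part of what the source reports. "The series", "measured", "known", "first", "only" and "open" are said of these compounds alone.

Three compounds sharing one core were measured in a functional assay on NCI-H460 cells (Homo sapiens) for inhibition, read by MTT assay, with a stated time of 72 h; a lower number here means a stronger inhibitor, a higher number a weaker inhibitor. Compound 1 `COc1cc2c(Oc3ccc(NC(=O)c4nn(-c5ccccc5)c(=O)cc4C)cc3F)ccnc2cc1OCCCN1CCCCC1` gives 280 nM. Going by the values given here, compound 2 `COc1cc2c(Oc3ccc(NC(=O)c4nn(-c5ccccc5C)c(=O)cc4C)cc3F)ccnc2cc1OCCCN1CCCCC1` gives 3220 nM; the step of a 12-fold higher number from compound 1 to compound 2 (1.06 log units; beyond the scatter) is the only single-point change measured, and it concerns a methyl on an aromatic carbon, not the chain end. Compound 3 `COc1cc2c(Oc3ccc(NC(=O)c4nn(-c5ccccc5C(F)(F)F)c(=O)cc4C)cc3F)ccnc2cc1OCCCN1CCCC1` gives 210 nM, the lowest of the three numbers, though it sits within the scatter of compound 1 and is separated from compound 2 by a gap beyond the scatter.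

Compound 4 `COc1cc2c(Oc3ccc(NC(=O)c4nn(-c5ccccc5C(F)(F)F)c(=O)cc4C)cc3F)ccnc2cc1OCCCN1CCCCC1` differs from compound 3 by piperidin-1-yl in place of pyrrolidin-1-yl on a saturated chain carbon, three bonds along the chain from an oxygen on an aromatic ring. Among the compounds with values here, no measured step bears on this exchange: compounds 1 and 2 both carry the piperidin-1-yl ring, and the one measured step changes a different part of the molecule. The closest guide is the pair of compound 3 and compound 1, which differ both in the ring at the chain end and in the trifluoromethyl versus hydrogen on the phenyl, and whose values lie within the scatter of each other. Compound 4 is therefore expected to show a step of a 1.1-fold higher number from compound 3 to compound 4 (0.04 log units; within the scatter) in this assay, no larger than the scatter and in no sure direction. Compound 4 is estimated at 230 nM, with a range from 100 nM to 550 nM.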

Compound 4, half-maximal inhibitory concentration: 210 nM
Estimate against measurement, compound 4: 1.1-fold (0.04 log units) above; the range from low to high includes it.
By their numbers in this assay, from the lowest: compounds 3, 4 and 1 (each within the scatter of the next); then compound 2.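

In this assay the exchange at the chain end can now be read on its own: no change at the digits printed from compound 3 to compound 4 (within the scatter) shows that, with trifluoromethyl on the phenyl, the six-membered piperidin-1-yl ring serves as well as the five-membered pyrrolidin-1-yl ring. Compound 4 also places trifluoromethyl directly against both other groups on the aromatic carbon in the piperidin-1-yl series: a 15-fold lower number from compound 2 to compound 4 (1.19 log units; beyond the scatter) is a large step for trifluoromethyl in place of methyl, while a 1.3-fold lower number from compound 1 to compound 4 (0.12 log units; within the scatter) for trifluoromethyl in place of hydrogen stays within the scatter, so among these three compounds only the methyl compound 2 stands apart. The data shown include no measurement that accounts for either result.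

On these data alone, the ring exchange is read only with trifluoromethyl on the phenyl, so it remains open whether the two rings would also match with hydrogen or methyl there. Also open, as far as these compounds go, is how a morpholine or a dimethylamine at the end of the propyl chain, or a longer chain carrying piperidine, would read in this assay.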